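Notes on the step from compound 2 to compound 3

The source may report more compounds than this note shows. Statements on the series, on what has been measured and on what is new or still open speak of the compounds shown alone.

In a functional assay on MDA cells (Homo sapiens) for inhibition, read by MTT assay, with a stated time of 48 h (on this read-out higher numbers stand for weaker inhibition and lower numbers for stronger inhibition), compound 1 (`O=C(CCCCOc1no[n+]([O-])c1S(=O)(=O)c1ccccc1)NO`) gives 2530 nM and compound 2 (`O=C(COCCOc1no[n+]([O-])c1S(=O)(=O)c1ccccc1)NO`) gives 15100 nM as the higher of the two numbers. Compound 3 (`CC(C)(COc1no[n+]([O-])c1S(=O)(=O)c1ccccc1)C(=O)NO`) awaits measurement. It has 1-(hydroxycarbamoyl)-1-methylethyl in place of ((hydroxycarbamoyl)methoxy)methyl on a saturated chain carbon bound to an oxygen on an aromatic ring. The chain of compound 3 holds no ether oxygen. Among the compounds with values here, one measured step bears on this, the modest 6.0-fold higher number from compound 1 to compound 2 (0.78 log units; beyond the scatter) on gaining such an oxygen, so a lower number is expected. The expected step is a 2.2-fold lower number from compound 2 to compound 3 (0.33 log units; beyond the scatter) and rests on that single case. Compound 3 is estimated at 7000 nM within an expected range of 2000 nM to 25000 nM on this read-out.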

Compound 3, half-maximal inhibitory concentration: 9550 nM
Beside the measured number, compound 3's estimate is 1.4-fold (0.13 log units) below it, within the range that was stated.
By their numbers in this assay, from the lowest: compound 1; then compounds 3 and 2 (each within the scatter of the next).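

In this assay, 1-(hydroxycarbamoyl)-1-methylethyl in place of ((hydroxycarbamoyl)methoxy)methyl gives a 1.6-fold lower number from compound 2 to compound 3 (0.20 log units; within the scatter), so at this position the chain without an ether oxygen is not separated from the chain with one. In place of 3-(hydroxycarbamoyl)propyl, the same group gives a 3.8-fold higher number from compound 1 to compound 3 (0.58 log units; beyond the scatter), which shows that an oxygen-free chain alone does not match compound 1. No supporting data explain either step.

The compounds shown leave open whether the gap to compound 1 follows the branching methyl groups or the chain length. On these data alone, a longer chain, or a carboxylic acid in place of the hydroxycarbamoyl group, also remains open.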